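Moving the Methyl Around the Pendant Phenyl Ring

A few compounds are considered here, and "the series" means these few. Any claim that something is new, unique, unknown or untested is made for them only; others in the source may bear on it.

Compound 1 `COc1ccc(Cl)cc1S(=O)(=O)Nc1cncc(-c2ccccc2C)c1` stands second highest of the three numbers in an assay on isolated protein for inhibition of alkaline phosphatase, tissue-nonspecific isozyme (Homo sapiens) (on this read-out higher numbers stand for weaker inhibition and lower numbers for stronger inhibition), where compound 1 gives 178 nM. Compound 3 `COc1ccc(Br)cc1S(=O)(=O)Nc1cccnc1` gives 43 nM, and compound 2 `COc1ccc(C(N)=O)cc1S(=O)(=O)Nc1cccnc1` gives 1490 nM. For the measured compounds named here, the single measured step between two compounds that differ in one place is a 35-fold lower number from compound 2 to compound 3 (1.54 log units; beyond the scatter), a bromo in place of carbamoyl on an aromatic carbon. Compound 4 `COc1ccc(Cl)cc1S(=O)(=O)Nc1cncc(-c2cccc(C)c2)c1` differs from compound 1 by 3-methylphenyl in place of 2-methylphenyl on an aromatic carbon. Going by the values given here, no measured step touches this methylphenyl group: the step from compound 2 to compound 3 concerns another part of the shared core, and compound 1 and compound 3 differ in more than one place, so their two values show only a gap that cannot be attributed to the methylphenyl group. With nothing pointing either way, compound 4 is expected to land close to compound 1, and the expected step of a 1.0-fold higher number from compound 1 to compound 4 (0.00 log units; within the scatter) should stay within the scatter. Compound 4 is estimated at 180 nM in this assay, with a range from 60 nM to 550 nM.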

Compound 4, half-maximal inhibitory concentration: 160 nM
For compound 4 the middle estimate is 1.1-fold (0.05 log units) above the measured one; low and high end bracket the measured number.
By their numbers in this assay, from the lowest: compound 3; then compounds 4 and 1 (each within the scatter of the next); then compound 2.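

In this assay, for the compounds shown here, the first measured step at the methylphenyl group is a 1.1-fold lower number from compound 1 to compound 4 (0.05 log units; within the scatter) and shows that 3-methylphenyl in place of 2-methylphenyl, a swap that keeps the same atoms, gives two values within the scatter of each other. Going by these compounds alone, on this aromatic carbon, two atoms from the ring nitrogen, the assay therefore does not separate these two methylphenyl groups, a comparison that the earlier compounds could not offer. No available evidence explains this match.

The compounds shown leave open how a plain phenyl group, or a carboxylic acid or an amine in place of the methyl, would read in this series. They also leave open what the methylphenyl group itself contributes, as compound 1 and compound 3 differ in more than one place.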